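The source may report more compounds than this note shows. Statements on the series, on what has been measured and on what is new or still open speak of the compounds shown alone.

Compound 2 `O=C(CN1CCN(c2nnc(Cc3ccncc3)c3ccccc23)CC1)Nc1cc(C(F)(F)F)ccc1Cl` is measured in a functional assay on HT-29 cells (Homo sapiens) for cytotoxicity, read by MTT assay, with a stated time of 72 h (on this read-out lower numbers stand for stronger inhibition and higher numbers for weaker inhibition), where compound 2 gives 4810 nM. Among the two compounds with numbers, this is the lowest; the nearest is compound 1 `Cc1cccc(Cl)c1NC(=O)CN1CCN(c2nnc(Cc3ccncc3)c3ccccc23)CC1`, for which compound 1 gives 22600 nM. For the measured compounds named here, the only measured step so far is a 4.7-fold lower number from compound 1 to compound 2 (0.67 log units; beyond the scatter).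

Compound 3 `Cc1ccc(F)cc1NC(=O)CN1CCN(c2nnc(Cc3ccncc3)c3ccccc23)CC1` has not yet been measured. It differs from compound 2 in one place: 5-fluoro-2-methylphenyl in place of 2-chloro-5-(trifluoromethyl)phenyl on an amide-type nitrogen. The group leaving and the group entering both sit on an amide-type nitrogen whose other neighbour is a carbonyl carbon.

Going by the values given here, the one step that bears on this change is the one from compound 1 to compound 2, which shows that changing the substituted phenyl on this nitrogen can move the number by a modest amount. Because compound 2 gives 4810 nM and compound 1 gives 22600 nM, and compound 3 keeps a group at the 5-position as in compound 2 but a methyl at the 2-position as in compound 1, the expected step for compound 3 is a 2.5-fold higher number from compound 2 to compound 3 (0.40 log units; beyond the scatter), a higher number. Compound 3 is estimated at 12000 nM, expected between 4000 nM and 35000 nM.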

Compound 3, half-maximal inhibitory concentration: 470 nM
Estimate against measurement, compound 3: 26-fold (1.41 log units) above; measured number outside the range, below it.
By their numbers in this assay, from the lowest: compound 3; then compound 2; then compound 1.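

In this assay the 5-fluoro-2-methylphenyl group on the amide-type nitrogen brings a 10-fold lower number from compound 2 to compound 3 (1.01 log units; beyond the scatter) and also a 48-fold lower number from compound 1 to compound 3 (1.68 log units; beyond the scatter) and so shows that this place can move the number much further than the first step suggested. A methyl on the phenyl ring does not settle the number by itself: compound 1 and compound 3 both carry one, yet they stand at opposite ends of the three compounds. Nothing measured here explains the size of this change. The compounds shown leave open whether the fluorine, the methyl or the pair of them goes with the low number of compound 3. They also leave open what a plain phenyl would give, or a phenyl carrying a methoxy group, an amine or a carboxylic acid.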